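Methyl for Hydrogen on the Ester Oxygen: Expected Effect

The compounds below may be only part of what the source reports. "The series", "measured", "known", "first", "only" and "open" are said of these compounds alone.

Measured so far in a functional assay on CCRF-CEM cells (Homo sapiens) for inhibition, read by MTT assay, with a stated time of 2 days, tested at 10 uM; a lower number here means less inhibition, a higher number more inhibition at the concentration tested (going by the name of the read-out):
compound 1 `COc1ccccc1-c1cn(-c2ccc(O)c(C(=O)OCCCc3ccccc3)c2)nn1` gives 4%
compound 2 `COc1ccccc1-c1cn(-c2ccc(O)c(C(=O)O)c2)nn1` gives 9%

Compound 2 holds the higher of these two numbers, yet the step of a number 5 percentage points higher from compound 1 to compound 2 (within the scatter) lies within the scatter, so the two compounds are not distinguishable on this evidence. Compound 3 `COC(=O)c1cc(-n2cc(-c3ccccc3OC)nn2)ccc1O` differs from compound 2 by methyl in place of hydrogen on an oxygen next to a carbonyl group. Among the compounds with values here, only one measured step bears on this position: from compound 1 to compound 2, a 3-phenylpropyl was removed from the same oxygen, and the read-out moved by a number 5 percentage points higher from compound 1 to compound 2 (within the scatter), inside the scatter. Adding a methyl there is a smaller change than removing a 3-phenylpropyl, so no step beyond the scatter is expected, and the estimated step is a number 1 percentage points lower from compound 2 to compound 3 (within the scatter). Compound 3 is therefore expected to give about 8%, with a likely range from 0% to 20%.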

Compound 3, a percentage reported as inhibition, at one concentration (the size of the read-out at that concentration, not a potency): 6%
Beside the measured number, compound 3's estimate is 2 percentage points above it, and the stated range covers the measured number.
By their numbers in this assay, from the lowest: compounds 1, 3 and 2 (each within the scatter of the next).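

Replacing the hydrogen of the carboxy group with a methyl gives a number 3 percentage points lower from compound 2 to compound 3 (within the scatter) in this assay, so a small ester can now be compared directly with the free acid. Exchanging the 3-phenylpropyl for the methyl gives a number 2 percentage points higher from compound 1 to compound 3 (within the scatter), which means that a short and a long ester group cannot be told apart here, and neither can be told apart from the free acid. Nothing available explains why these changes on this oxygen leave the read-out within the scatter.

Going by these compounds, it remains open whether an amide formed with a simple amine at this carbonyl, or a chain ending in an amine on this oxygen, would give a step beyond the scatter. On these data alone, whether changes elsewhere on the shared core would do so also remains open.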